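The source may hold more compounds than are shown below. What is called first, only, known or untested is meant among the compounds shown, and "the series" means these compounds.

Two compounds from this set have been run in a functional assay on the whole organism (strain Swiss albino) with Mus musculus as the target, in the forced swim test, with a stated time of 5 min, at a dose of 0.5 mg/kg by the intraperitoneal route; on this read-out higher numbers stand for more inhibition at the one dose given (going by the name of the read-out) and lower numbers for less inhibition. Compound 1, `COc1cc(-c2cc3cc(C4C(C#N)=C(N)OC5=C4C(=O)CC(C)(C)C5)cc(C)c3oc2=O)cc(OC)c1OC`, gives 6.37% in this assay. Compound 2, `COc1ccc(-c2cc3cc(C4C(C#N)=C(N)OC5=C4C(=O)CCC5)cc(C(C)C)c3oc2=O)cc1`, gives 69.7% in this assay, the higher of the two numbers, and its gap to compound 1 lies beyond the usual scatter of this kind of measurement. The two compounds differ in several places at once, so no single structural change can be read from that gap.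

Compound 3, `COc1ccc(-c2cc3cc(C4C(C#N)=C(N)OC5=C4C(=O)CCC5)cc(C(C)C)c3oc2=O)cc1OC`, has not been measured. It differs from compound 2 in one place: methoxy in place of hydrogen on an aromatic carbon. Cut one bond further out, the change reads as a 4-methoxyphenyl group becoming a 3,4-dimethoxyphenyl group. Among the measured compounds shown here, since no single-change step between measured compounds exists here, the direction of this change can only be estimated. A modest drop is expected, a step of a number 14.7 percentage points lower from compound 2 to compound 3 (beyond the scatter), on the reasoning that compound 1, carrying a more heavily methoxylated aromatic ring among its other differences, gives only 6.37%. Compound 3 is therefore expected to give about 55% in this assay, within a range from 30% to 75%.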

Compound 3, a percentage reported as inhibition, in the whole organism at one dose (the size of the read-out at that dose, not a potency): 57.2%
The estimate for compound 3 lay 2.2 percentage points below the measured number; measured number inside the range.
By their numbers in this assay, from the lowest: compound 1; then compound 3; then compound 2.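

Placing methoxy on this aromatic carbon, which turns the 4-methoxyphenyl group into a 3,4-dimethoxyphenyl group, gives the first single-place comparison in this assay, and the result is a number 12.5 percentage points lower from compound 2 to compound 3 (beyond the scatter). The position therefore accepts this added group at a modest cost, with compound 3 still giving 57.2% at the one dose tested, so the extra methoxy lowers the read-out without abolishing it. Nothing measured in this set explains why the number falls with this change.

A single replacement at a single position cannot show whether the drop is specific to methoxy or would follow from other groups on the same carbon, such as hydroxy, a chlorine atom, an amine or a longer ethoxy chain. The compounds shown also leave open how the 4-methoxy group itself contributes, which a phenyl ring without it or with a hydroxy group in its place would begin to answer.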